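This account rests on a few compounds, and the source may have more. Where it says the series, first, only, none or still open, it means among the compounds named here.

Compounds measured in this study:
compound 1, `CC(C)(C)C[C@@H](O)C(=O)N1[C@@H]2C[C@@H]2C[C@H]1C(=O)NCc1cc(Cl)ccc1-n1cnnn1`, 71 mL.min-1.g-1
compound 2, `CC1(C[C@@H](O)C(=O)N2N=CC[C@H]2C(=O)NCc2cc(Cl)ccc2-n2cnnn2)CC1`, < 12 mL.min-1.g-1
compound 3, `O=C(NCc1cc(Cl)ccc1-n1cnnn1)[C@@H]1CCON1C(=O)[C@H](O)c1ccccc1`, < 12 mL.min-1.g-1

In an ADME assay on liver for metabolic stability, with Liver microsome (Homo sapiens) as the target, read by LC-MS, using microsomes (on this read-out lower numbers stand for slow clearance and higher numbers for fast clearance), compound 1 gives 71 mL.min-1.g-1. For compound 2 the assay reports only a limit, < 12 mL.min-1.g-1, not a number. For compound 3 likewise only a limit is reported, < 12 mL.min-1.g-1. Within the data shown here, compound 2 thus stands at the limit of < 12 mL.min-1.g-1 in this assay, at which 2 of the 3 values shown sit, the lower edge of what this assay reads, with compound 1 as the one numbered value that lies above it.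

Compound 4, `O=C(NCc1cc(Cl)ccc1-n1cnnn1)[C@@H]1CC=NN1C(=O)[C@H](O)c1ccccc1F`, has not yet been measured in this assay. It differs from compound 2 in one place: 2-fluorophenyl in place of (1-methylcyclopropyl)methyl on a saturated chain carbon bound to a carbonyl carbon and an oxygen on a saturated carbon. Among the measured compounds shown here, no step between two measured compounds matches this change, so there is no measured precedent for its size. Compound 2 already sits at the limit of this assay. The step is therefore expected to be none beyond the scatter, a step that the limit leaves unreadable from compound 2 to compound 4, and another limit rather than a number is the most likely outcome. Compound 4 is estimated to give 10 mL.min-1.g-1 in this assay, within 4 mL.min-1.g-1 to 25 mL.min-1.g-1.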

Compound 4, intrinsic clearance in microsomes: 16 mL.min-1.g-1
Estimate against measurement, compound 4: 1.6-fold (0.20 log units) below; the measured number falls inside the stated range.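

In this assay, with 2-fluorophenyl on a saturated chain carbon bound to a carbonyl carbon and an oxygen on a saturated carbon, compound 4 gives a true number rather than a limit, so this change at this position yields a value that can be read. Compound 2 is reported only as a limit, < 12 mL.min-1.g-1. The change therefore gives an at least 1.3-fold higher number from compound 2 to compound 4 (0.12 log units; that floor lies within the scatter), and its real size cannot be told because the starting point is a limit: the limit of < 12 mL.min-1.g-1 in this assay, at which 2 of the 4 values shown sit.

The compounds shown leave open what plain phenyl would give at this place on the core of compound 4, and so how much of the change belongs to the fluorine and how much to the ring. They also leave open whether an aminomethyl or a longer alkyl chain at this place would give a number or a limit.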